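Swapping an ester link for a benzyl on the shared core

A few compounds are considered here, and "the series" means these few. Any claim that something is new, unique, unknown or untested is made for them only; others in the source may bear on it.

Of the compounds shown here, three built on one shared core have been tested so far in a functional assay on HCC827 cells (Homo sapiens) for inhibition, read by MTT assay, with a stated time of 72 h (a lower number here means a stronger inhibitor, a higher number a weaker inhibitor), and only one gave a true reading. Compound 1 (`CC(=O)Oc1ccc(C(=O)C2=C(O)[C@]3(CC=C(C)C)C[C@@H](C/C=C(\C)CCC=C(C)C)[C@](C)(CCC=C(C)C)[C@](CC=C(C)C)(C2=O)C3=O)cc1OC(C)=O`) gives > 20000 nM here, which is a limit of the assay and not a number. Compound 2 (`CC(C)=CCC/C(C)=C/C[C@@H]1C[C@]2(CC=C(C)C)C(=O)[C@@](CC=C(C)C)(C(=O)C(C(=O)c3ccc(O)c(OC(=O)CCCC[C@@H]4SCC5NC(=O)NC54)c3)=C2O)[C@@]1(C)CCC=C(C)C`) gives 12100 nM as a real measured value. As far as these compounds go, compound 3 (`CC(C)=CCC/C(C)=C/C[C@@H]1C[C@]2(CC=C(C)C)C(=O)[C@@](CC=C(C)C)(C(=O)C(OC(=O)c3ccc(O)c(O)c3)=C2O)[C@@]1(C)CCC=C(C)C`) gives > 20000 nM too, again a limit and not a number, so its true strength is unknown.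

Compared with compound 3, compound 4 (`CC(C)=CCC/C(C)=C/C[C@@H]1C[C@]2(CC=C(C)C)C(=O)[C@@](CC=C(C)C)(C(=O)C(Cc3ccc(O)c(O)c3)=C2O)[C@@]1(C)CCC=C(C)C`) has 3,4-dihydroxybenzyl in place of ((3,4-dihydroxyphenyl)carbonyl)oxy on a double-bonded ring carbon of the shared core.

Among the compounds with values here, with no measured step to lean on, only a modest gain in strength is expected, since compound 2 reaches just 12100 nM in this assay. A weak reading seems likely. The expected change is an at least 1.3-fold lower number from compound 3 to compound 4 (0.12 log units; that floor lies within the scatter) and it remains uncertain. Compound 4 is estimated to read 15000 nM with a range from 7000 nM to 30000 nM expected for repeated measurements.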

Compound 4, half-maximal inhibitory concentration: > 20000 nM
Compound 4: no number, only a limit; the forecaster's own chance of this, stated with the estimate: 50%; middle value at least 1.3-fold (0.12 log units) from the limit.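

In this assay compound 4 gives > 20000 nM, a limit and not a number. Within the data shown here, compound 3 also sits at a limit, so no step between compound 3 and compound 4 can be read. As far as these compounds go, whether swapping the ester link for 3,4-dihydroxybenzyl changes strength at all stays open.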